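Series notes: chain length on the lactam core

The compounds below may be only part of what the source reports. "The series", "measured", "known", "first", "only" and "open" are said of these compounds alone.

Measured so far:
compound 1, `COC(=O)N(C)c1c(N)nc(-n2nc(Cc3ccccc3F)c3cc(F)ccc32)nc1N`, 960 nM
compound 2, `CCCc1nn(-c2nc(N)c3c(n2)NC(=O)C3(C)C)c2ccc(Cl)cc12`, 546000 nM
compound 3, `COC(=O)N(C)c1c(N)nc(-n2nc(Cc3c(F)ccc(F)c3F)c3ccccc32)nc1N`, 270 nM

All three values come from an assay on CHO cells for activation of soluble guanylate cyclase alpha1/beta1 complex (Homo sapiens), read by cGMP accumulation; a lower number here means that less compound is needed, a higher number that more compound is needed for the effect. Compound 2 stands at the highest number of the three; its gaps to compound 1 and to compound 3 both lie well beyond the scatter, so among the measured compounds it needs by far the most material for the effect. Compounds 1 and 3 share a different core and carry a substituted benzyl group, whereas compound 2 carries a propyl chain on its own core, so no single-change comparison to compound 2 exists among the measured set.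

The next compound, compound 4, `CCCCCc1nn(-c2nc(N)c3c(n2)NC(=O)C3(C)C)c2ccc(Cl)cc12`, keeps the core of compound 2 and changes only the chain: ethyl in place of hydrogen on a saturated chain carbon, three bonds along the chain from an aromatic carbon. Among the compounds with values here, no measured pair isolates this change, so the direction of the step is open. Within the data shown here, a small shift is thought the most likely outcome, with the wide uncertainty that the single very high starting value of compound 2 in this assay carries.

Compound 4 is expected at 350000 nM, within the range 60000 nM to 1500000 nM. The estimated step of a 1.6-fold lower number from compound 2 to compound 4 (0.19 log units; within the scatter) is expected to stay close to the scatter.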

Compound 4, half-maximal effective concentration: 90000 nM
The estimate for compound 4 lay 3.9-fold (0.59 log units) above the measured number, within the range that was stated.
By their numbers in this assay, from the lowest: compound 3; then compound 1; then compound 4; then compound 2.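

In this assay, within the data shown here, extending the propyl chain of compound 2 to the pentyl chain of compound 4 gives a 6.1-fold lower number from compound 2 to compound 4 (0.78 log units; beyond the scatter), the only single-change comparison available so far. The earlier compounds shown here offered no pair that isolated this position; this pair shows that, on this core, the number responds to ethyl in place of hydrogen on a saturated chain carbon, three bonds along the chain from an aromatic carbon, and that the longer chain goes with less compound being needed for the effect. No accompanying measurement speaks to why the number moves, so the step stands as an observation from a single pair.

Going by these compounds, with only propyl and pentyl on this core, the shape of the chain-length trend remains open: butyl could show whether the change is gradual, and a longer chain such as hexyl or octyl could show whether the direction continues or reverses. Also open, on these data alone, is how this position responds to other kinds of group on the same core, such as a chain ending in an amine or a carboxylic acid, or a benzyl group.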